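Adding a Second Chloro to the Amide Aryl Ring

This account rests on a few compounds, and the source may have more. Where it says the series, first, only, none or still open, it means among the compounds named here.

Three amides that share one core have been measured in an assay on LtK cells with ATP-sensitive inward rectifier potassium channel 11 (Homo sapiens) as the target; on this read-out higher numbers stand for an effect only at larger amounts of compound and lower numbers for an effect already at smaller amounts. Compound 1 `CC(=O)Nc1c(C(O)(C(F)(F)F)C(F)(F)F)ccc2ccccc12` gives 18 nM, compound 2 `O=C(CCc1ccccc1)Nc1c(C(O)(C(F)(F)F)C(F)(F)F)ccc2ccccc12` gives 1750 nM, and compound 3 `O=C(Nc1c(C(O)(C(F)(F)F)C(F)(F)F)ccc2ccccc12)c1cccc(Cl)c1` gives 98 nM. Compound 3 thus stands second highest of the three numbers, with a 5.4-fold higher number from compound 1 to compound 3 (0.74 log units; beyond the scatter) placing it above compound 1 and an 18-fold lower number from compound 2 to compound 3 (1.25 log units; beyond the scatter) placing it well below compound 2. Compound 4 `O=C(Nc1c(C(O)(C(F)(F)F)C(F)(F)F)ccc2ccccc12)c1ccc(Cl)c(Cl)c1` is not yet measured. Its difference from compound 3 is chloro in place of hydrogen on an aromatic carbon, so that 3-chlorophenyl becomes 3,4-dichlorophenyl. For the measured compounds named here, none of the measured steps bears directly on this change: a 97-fold higher number from compound 1 to compound 2 (1.99 log units; beyond the scatter), a 5.4-fold higher number from compound 1 to compound 3 (0.74 log units; beyond the scatter) and an 18-fold lower number from compound 2 to compound 3 (1.25 log units; beyond the scatter) each exchange the whole group on the carbonyl carbon, whereas here a single chloro is added to a ring that already carries one. With no measured guide to size or direction, for compound 4 a step within the scatter is expected: a 1.0-fold higher number from compound 3 to compound 4 (0.01 log units; within the scatter). Compound 4 is therefore estimated at 100 nM, with a range from 35 nM to 300 nM.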

Compound 4, half-maximal effective concentration: 194 nM
Beside the measured number, compound 4's estimate is 1.9-fold (0.29 log units) below it; measured number inside the range.
By their numbers in this assay, from the lowest: compound 1; then compounds 3 and 4 (each within the scatter of the next); then compound 2.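

In this assay, adding a chloro to the aromatic ring, ortho to the chloro group already there, gives a 2.0-fold higher number from compound 3 to compound 4 (0.30 log units; within the scatter) and so shows no change that can be told apart from repeat scatter. This ring position therefore accepts the second chloro, and the 3,4-dichlorophenyl amide still sits apart from both other amides (a 9.0-fold lower number from compound 2 to compound 4 (0.96 log units; beyond the scatter)) and (an 11-fold higher number from compound 1 to compound 4 (1.03 log units; beyond the scatter)). No supporting data are available to explain this result.

The compounds shown leave open how a fluoro, a methoxy or an amine on the same ring carbon would read, and whether a 4-chlorophenyl group without the first chloro would read like compound 4. They also leave open whether an ethyl or a cyclopropyl on the carbonyl carbon would come close to compound 1 at 18 nM in this series.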